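A few compounds are considered here, and "the series" means these few. Any claim that something is new, unique, unknown or untested is made for them only; others in the source may bear on it.

Of the compounds shown here, three sharing one core have been measured in a functional assay on SH-SY5Y cells (Homo sapiens) for antiproliferative activity, read by MTT assay, with a stated time of 72 h; on this read-out lower numbers stand for stronger inhibition and higher numbers for weaker inhibition. Compound 1 `COc1cc2c(Nc3ccc(C#N)cc3)ncnc2cc1OCCCN(C)C` gives 34900 nM in this assay. Compound 3 `COc1cc2c(Nc3ccc(C#N)cc3)ncnc2cc1OCCCN1CCC(c2ccccc2)CC1` gives 7770 nM. Compound 2 `COc1cc2c(Nc3ccc(C#N)cc3)ncnc2cc1OCCCN(C)Cc1ccccc1` reaches only the limit of > 100000 nM, so no number is known for it, and it sits at the limit of > 100000 nM in this assay, at which 1 of the 3 values shown sits. Among the measured steps, an at least 2.8-fold higher number from compound 1 to compound 2 (0.45 log units; beyond the scatter), whereas a 4.5-fold lower number from compound 1 to compound 3 (0.65 log units; beyond the scatter) and an at least 12-fold lower number from compound 2 to compound 3 (1.10 log units; beyond the scatter).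

Compound 4 `COc1cc2c(Nc3ccc(C#N)cc3)ncnc2cc1OCCCN1CCC(N2CCCCC2)CC1` has yet to be measured; it differs from compound 2 by 4-(piperidin-1-yl)piperidin-1-yl in place of benzyl(methyl)amino on a saturated chain carbon, three bonds along the chain from an oxygen on an aromatic ring. The step that bears on this most closely is the one in which the benzyl(methyl)amino group of compound 2 was replaced by the ring-bearing 4-phenylpiperidin-1-yl amine of compound 3, a large lowering of the number. Compound 4 likewise replaces that group with a ring-bearing amine, so a lowering of comparable size is expected, though the second ring is now saturated rather than aromatic, which keeps the expectation cautious. The expected step is an at least 6.6-fold lower number from compound 2 to compound 4 (0.82 log units; beyond the scatter). Compound 4 is therefore estimated at 15000 nM, within a range from 4000 nM to 60000 nM.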

Compound 4, half-maximal inhibitory concentration: 9810 nM
Estimate against measurement, compound 4: 1.5-fold (0.18 log units) above, within the range that was stated.
By their numbers in this assay, from the lowest: compounds 3 and 4 (each within the scatter of the next); then compound 1. At a limit, above all of these: compound 2.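

In this assay, piperidin-1-yl in place of phenyl on a saturated ring carbon gives a 1.3-fold higher number from compound 3 to compound 4 (0.10 log units; within the scatter), so an aromatic ring at the far end of this amine is not required for a value in this range. The advantage over the dimethylamino group holds with this second ring-bearing amine, at a 3.6-fold lower number from compound 1 to compound 4 (0.55 log units; beyond the scatter). Carrying a ring is not enough by itself, however: benzyl(methyl)amino carries one too, yet 4-(piperidin-1-yl)piperidin-1-yl gives an at least 10-fold lower number from compound 2 to compound 4 (1.00 log units; beyond the scatter).

Going by these compounds, the true size of that last step remains open, since compound 2 gives no number, only a limit: the limit of > 100000 nM in this assay, at which 1 of the 4 values shown sits. Also open is whether a morpholine, a 4-methylpiperazine or a longer chain at this place would give similar values.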